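Dichloromethyl for piperidinylmethyl on an ester of a nitroimidazole

The source may hold more compounds than are shown below. What is called first, only, known or untested is meant among the compounds shown, and "the series" means these compounds.

Compound 1 `Cc1ncc([N+](=O)[O-])n1CCSC(=S)N1CCC(OC(=O)CN2CCCCC2)CC1`: 760 ug/mL
Compound 2 `CCC1CCCCN1C(=S)SCCn1c([N+](=O)[O-])cnc1C`: 94 ug/mL

Of the compounds shown here, two have been measured in an ADME assay on HeLa cells (Homo sapiens) for cytotoxicity; a lower number here means a stronger inhibitor, a higher number a weaker inhibitor. Compound 1 gives 760 ug/mL there, the highest of the two numbers; compound 2 gives 94 ug/mL, a lower number, and the gap between the two lies beyond the usual scatter. For the measured compounds named here, since compound 1 and compound 2 differ in more than one place, no single step between them can be read off; only their two values stand side by side.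

Compound 3 `Cc1ncc([N+](=O)[O-])n1CCSC(=S)N1CCC(OC(=O)C(Cl)Cl)CC1` has not yet been measured in this assay. It differs from compound 1 in one place: dichloromethyl in place of (piperidin-1-yl)methyl on a carbonyl carbon. The shared core and the rest of the ester are unchanged.

Going by the values given here, there is no measured step of this kind to lean on, so any expectation rests only on compound 1 and the change. Because compound 1 gives 760 ug/mL, the step to compound 3 is expected to be moderate and towards a lower number, a 2.5-fold lower number from compound 1 to compound 3 (0.40 log units; beyond the scatter). Compound 3 is estimated at 300 ug/mL, with a range from 100 ug/mL to 800 ug/mL.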

Compound 3, half-maximal inhibitory concentration: > 1000 ug/mL
Compound 3 gave a limit, no number; the forecaster's own chance of this, stated with the estimate: 5%; at least 3.3-fold (0.52 log units) between middle value and limit.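

In this assay compound 3 gives > 1000 ug/mL, which is a limit of the assay and not a number. For the compounds shown here, on the carbonyl carbon, dichloromethyl in place of (piperidin-1-yl)methyl gives an at least 1.3-fold higher number from compound 1 to compound 3 (0.11 log units; that floor lies within the scatter), so this exchange, the first single change that can be read at this position, brought no move towards a lower number, although the floor of the step does not establish a real rise. The piperidine ring of this ester is thus not needed for a number as high as that of compound 1, and the reading for compound 3 reaches the end of what the assay reports: the limit of > 1000 ug/mL in this assay, at which 1 of the 3 values shown sits.

Going by these compounds, how far compound 3 truly lies from compound 1 stays open, as only a floor is known for the step. Also open, on these data alone, is whether a small amine such as dimethylamino, a plain methyl or a carboxylic acid on the same carbonyl carbon would give a number that can be read, and so show how far this position can move the value in this assay.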